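Cytotoxicity limits across benzyl ether variants

The source may report more compounds than this note shows. Statements on the series, on what has been measured and on what is new or still open speak of the compounds shown alone.

Measured in an ADME assay on Vero cells (Chlorocebus sabaeus) for cytotoxicity, read by sulforhodamine B assay, with a stated time of 72 h; on this read-out higher numbers stand for weaker inhibition and lower numbers for stronger inhibition:
compound 1 `CN1Cc2ccc(OCc3ccccc3)cc2[C@@H](O)C1`, a limit only: > 100000 nM
compound 2 `Cc1ccccc1COc1ccc2c(c1)[C@@H](O)CN(C)C2`, a limit only: > 100000 nM
compound 3 `CN1Cc2ccc(OCCc3ccccc3)cc2[C@@H](O)C1`, a limit only: > 50000 nM

Compound 3 gives only a limit in this assay, not a number. For that reason the steps a step that the two limits leave unreadable from compound 1 to compound 3 and a step that the two limits leave unreadable from compound 2 to compound 3 cannot be read, and neither can a step that the two limits leave unreadable from compound 1 to compound 2. Compound 4 `CN1Cc2ccc(OCc3cccnc3)cc2[C@@H](O)C1` differs from compound 3 by pyridin-3-yl in place of benzyl on a saturated chain carbon bound to an oxygen on an aromatic ring. Among the compounds with values here, no measured step speaks readably to this change; what the series shows is the limit of > 100000 nM in this assay, at which 2 of the 3 values shown sit, and (the limit of > 50000 nM in this assay, at which 1 of the 3 values shown sits). The step that the limit leaves unreadable from compound 3 to compound 4 is accordingly expected to be none beyond the scatter, and compound 4 is estimated at 150000 nM in this assay, with a range from 40000 nM to 500000 nM, most likely reported as a limit again.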

Compound 4, half-maximal inhibitory concentration: > 50000 nM
Compound 4 ended at the assay's limit; the forecaster's own chance of this, stated with the estimate: 85%; the middle value is on the limit's open side.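

In this assay compound 4 gives > 50000 nM, a limit only. The steps to compound 4 from compound 1, compound 2 and compound 3 therefore cannot be read. The compounds shown leave open whether these four compounds differ in cytotoxicity at all, since none has a value that is a number.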